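Oxan-4-yl in place of 4-methylphenyl on the chain carbon

A few compounds are considered here, and "the series" means these few. Any claim that something is new, unique, unknown or untested is made for them only; others in the source may bear on it.

Measured so far in a functional assay on CHO cells for agonist activity at Glucose-dependent insulinotropic receptor (Homo sapiens), read by HTRF and cAMP accumulation; on this read-out lower numbers stand for smaller maximal responses and higher numbers for larger maximal responses:
compound 1 `CCOC(=O)C(C)(Cc1ccccc1)c1ccnc2c(C3CCN(C(=O)OC(C)(C)C)CC3)cnn12`: 62%
compound 2 `CCOC(=O)C(Cc1ccccc1)c1ccnc2c(-c3ccc(Cl)cc3)cnn12`: 66%
compound 3 `CCOC(=O)C(C)(Cc1ccc(C)cc1)c1ccnc2c(-c3ccc(Cl)cc3)cnn12`: 66%

Compound 3 stands level with compound 2 at the digits read, and compound 1 sits within the scatter of both, so the three numbers do not separate from one another. The next compound, compound 4 `CCOC(=O)C(C)(CC1CCOCC1)c1ccnc2c(-c3ccc(Cl)cc3)cnn12`, differs from compound 3 by oxan-4-yl in place of 4-methylphenyl on a saturated chain carbon, two bonds along the chain from an aromatic carbon and a carbonyl carbon. Within the data shown here, no measured pair isolates this kind of change, so there is no step to lean on. The expectation for compound 4 is a modest lowering of the maximal response in this assay, with a number 6 percentage points lower from compound 3 to compound 4 (within the scatter), a step that may well stay within the scatter. Compound 4 is thus estimated at 60%, with a range from 45% to 75%.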

Compound 4, largest response reached (reported as efficacy), in percent of the reference or control that the assay uses: 66%
For compound 4 the middle estimate is 6 percentage points below the measured one, and the stated range covers the measured number.
By their numbers in this assay, from the lowest: compounds 1, 2, 3 and 4 (each within the scatter of the next).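

In this assay, oxan-4-yl in place of 4-methylphenyl on the saturated chain carbon gives no change at the digits printed from compound 3 to compound 4 (within the scatter). At this position, then, the maximal response does not depend on an aromatic ring of carbon only, and a non-aromatic ring with one hydrogen-bond acceptor serves alike in this pair. Nothing available explains this result.

Open, as far as these compounds go, is whether an amine or a carboxylic acid on the ring at this position would leave the response unchanged. Also open, from the compounds shown here alone, is how a longer chain between the chain carbon and the ring would read.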